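Expected inhibition for compound 3 after the ring change

The compounds below may be only part of what the source reports. "The series", "measured", "known", "first", "only" and "open" are said of these compounds alone.

Going by the values given here, compound 2 `C(=C/c1ccccc1OCCCCN1CCCC1)\c1ccccc1` gives 87.5% in a functional assay on the whole organism with Mus musculus as the target, at a dose of 50 mg/kg by the oral route (a higher number here means more inhibition at the dose given (going by the name of the read-out), a lower number less inhibition), the higher of the two numbers measured so far. Among the compounds with values here, compound 1 `CN(C)CCCCOc1ccccc1/C=C/c1ccc(Cl)cc1` gives 62.5% in this assay, a number below compound 2 by more than the usual scatter; compound 1 differs from compound 2 in more than one place, so no single step is drawn between them. Compound 3 `OC1CCN(CCCCOc2ccccc2/C=C/c2ccccc2)CC1` is not yet measured and differs from compound 2 in one place: 4-hydroxypiperidin-1-yl in place of pyrrolidin-1-yl on a saturated chain carbon, four bonds along the chain from an oxygen on an aromatic ring. Within the data shown here, no measured pair shows this change, so the step of a number 9.5 percentage points lower from compound 2 to compound 3 (within the scatter) is expected to be small, a slight fall at most, not beyond the usual scatter. Compound 3 is therefore estimated at 78% in this assay, between 55% and 95%.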

Compound 3, a percentage reported as inhibition, in the whole organism at one dose (the size of the read-out at that dose, not a potency): 50%
For compound 3 the middle estimate is 28 percentage points above the measured one; measured number outside the range, below it.
By their numbers in this assay, from the lowest: compound 3; then compound 1; then compound 2.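

Notes on the chain end: on a saturated chain carbon, four bonds along the chain from an oxygen on an aromatic ring, the choice of amine matters in this assay. 4-hydroxypiperidin-1-yl in place of pyrrolidin-1-yl gives a number 37.5 percentage points lower from compound 2 to compound 3 (beyond the scatter), the first change at a single place that can be read in this series. No measurement available bears on the reason for this fall.

The step alters ring size and adds a hydroxy group together, and the compounds shown do not separate the two. Unsubstituted piperidin-1-yl on the same chain would tell them apart.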